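From methyl to chloro at an assay limit

A few compounds are considered here, and "the series" means these few. Any claim that something is new, unique, unknown or untested is made for them only; others in the source may bear on it.

- Compound 1 (`C=C(CC)C(=O)c1ccc(OCC(=O)O)cc1C`) gives > 60000 nM (a limit)
- Compound 2 (`C=C(CCC)C(=O)c1ccc(OC(C)C(=O)OC)c(C)c1C`) gives 5600 nM (a number)
- Compound 3 (`C=C(CC)C(=O)c1ccc(OC(C)C(=O)O)cc1C`) gives > 60000 nM (a limit)

These values come from a functional assay on HL-60 cells (Homo sapiens) for antiproliferative activity, with a stated time of 72 h (on this read-out higher numbers stand for weaker inhibition of growth and lower numbers for stronger inhibition of growth), and compound 1 has no number there, only a limit. It stands with compound 3 at the limit of > 60000 nM in this assay, at which 2 of the 3 values shown sit, and so offers no exact starting point. Within the data shown here, compound 2 alone has a number, but no single-place step links it to compound 1.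

Compound 4 (`C=C(CC)C(=O)c1ccc(OCC(=O)O)cc1Cl`) has chloro in place of methyl on an aromatic carbon of the core of compound 1 (chloro in place of methyl on an aromatic carbon) and is not yet measured. Among the measured compounds shown here, the only measured step is a step that the two limits leave unreadable from compound 1 to compound 3 and it lies at a different place, so it gives no size for this change. No step beyond the scatter is therefore expected, and this assay may again report only a limit. The expected step is a number no higher from compound 1 to compound 4 (the limit leaves the size open) on this estimate. Compound 4 is estimated at 60000 nM with an expected range from 20000 nM to 120000 nM in this read-out.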

Compound 4, concentration for 50% growth inhibition: > 60000 nM
Compound 4: only a limit was reported; the forecaster's own chance of this, stated with the estimate: 70%; the middle value sits exactly at the limit.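

In this assay compound 4 gives > 60000 nM, which is a limit, and compound 1 also has only a limit, so no step between compound 1 and compound 4 can be read: the limit of > 60000 nM in this assay, at which 3 of the 4 values shown sit.

The compounds shown leave open whether chloro in place of methyl on an aromatic carbon alters growth inhibition at all.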